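A few compounds are considered here, and "the series" means these few. Any claim that something is new, unique, unknown or untested is made for them only; others in the source may bear on it.

Compound 1 `Cc1cc2occ(-c3nc(-c4ccccc4)c(-c4ccccc4)n3-c3ccc([N+](=O)[O-])cc3)c(=O)c2cc1Cl` was tested in an ADME assay on MCF-10A cells (Homo sapiens) for cytotoxicity, read by MTT assay, with a stated time of 72 h; a higher number here means a weaker inhibitor, a lower number a stronger inhibitor. In this assay compound 1 gave no number but a limit, > 100000 nM. That reading is the limit of > 100000 nM in this assay, at which 1 of the 2 values shown sits. Compound 2 `COc1ccccc1-n1c(-c2coc3cc(C)c(Cl)cc3c2=O)nc(-c2ccccc2)c1-c1ccccc1` stands on no number at all: in this assay compound 2 is recorded as "not determined" (no result reported). Compound 3 `Cc1cc2occ(-c3nc(-c4ccccc4)c(-c4ccccc4)n3-c3ccc(Cl)c(Cl)c3)c(=O)c2cc1Cl` differs from compound 2 by 3,4-dichlorophenyl in place of 2-methoxyphenyl on an aromatic nitrogen. Among the compounds with values here, with no measured step between these compounds to draw on, no shift beyond the usual scatter is expected in this assay from this change. For compound 3 the value in this assay is estimated at 150000 nM, with a range from 40000 nM to 500000 nM, and it is expected most likely to be reported again only as a limit.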

Compound 3, half-maximal inhibitory concentration: 98000 nM
Beside the measured number, compound 3's estimate is 1.5-fold (0.18 log units) above it; measured number inside the range.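

In this assay, within the data shown here, compound 3 gives the first actual number for a group on this aromatic nitrogen, 98000 nM. Setting 3,4-dichlorophenyl in place of 4-nitrophenyl gives an at least 1.0-fold lower number from compound 1 to compound 3 (0.00 log units; that floor lies within the scatter), so this change shows no firm shift. The step stays open-ended because compound 1 is recorded only as a limit: the limit of > 100000 nM in this assay, at which 1 of the 3 values shown sits.

The compounds shown leave open whether a phenyl group carrying an amine or a carboxylic acid on this nitrogen would bring the number down. They also leave open what a longer chain there would do.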